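The source may report more compounds than this note shows. Statements on the series, on what has been measured and on what is new or still open speak of the compounds shown alone.

Three compounds that share one core, and differ only in the group on their double-bonded chain, have been tested so far in a functional assay, read by spectrophotometry, tested at 100 uM (on this read-out lower numbers stand for stronger inhibition and higher numbers for weaker inhibition), as a common measure. Compound 1 `O=C(/C=C/c1cccc2ccccc12)c1cccc(NC(=O)c2cc(-c3ccncc3)n[nH]2)c1` carries naphthalen-1-yl and gives 64500 nM as its reading. Compound 2 `O=C(/C=C/c1ccc(F)cc1)c1cccc(NC(=O)c2cc(-c3ccncc3)n[nH]2)c1` carries 4-fluorophenyl and gives 56000 nM as its reading. Compound 3 `O=C(/C=C/c1ccccc1Cl)c1cccc(NC(=O)c2cc(-c3ccncc3)n[nH]2)c1` carries 2-chlorophenyl and stands lowest of the three at 27700 nM on these numbers.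

Compound 4 `O=C(/C=C/c1ccc(Cl)cc1Cl)c1cccc(NC(=O)c2cc(-c3ccncc3)n[nH]2)c1` differs from compound 3 by one change, chloro in place of hydrogen on an aromatic carbon so that 2-chlorophenyl becomes 2,4-dichlorophenyl. Within the data shown here, no tested pair shows chloro in place of hydrogen directly, so the guides are swaps of that same group: a 2.0-fold lower number from compound 2 to compound 3 (0.31 log units; beyond the scatter) and a 2.3-fold lower number from compound 1 to compound 3 (0.37 log units; beyond the scatter) are modest, while a 1.2-fold lower number from compound 1 to compound 2 (0.06 log units; within the scatter) stays within the scatter. In this assay a step no larger than these modest ones is therefore expected, slightly downward and most likely within the scatter. The estimated change is a 1.3-fold lower number from compound 3 to compound 4 (0.12 log units; within the scatter) and so remains small. For compound 4 the expected value is 21000 nM as a best guess. The estimated range for compound 4 runs from 10000 nM to 42000 nM on this read-out.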

Compound 4, half-maximal inhibitory concentration: 35000 nM
Compound 4: middle estimate off by 1.7-fold (0.22 log units), on the low side; measured number inside the range.
By their numbers in this assay, from the lowest: compounds 3, 4, 2 and 1 (each within the scatter of the next, the first and the last beyond it).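

In this assay, adding a chloro para to a large group, which turns 2-chlorophenyl into 2,4-dichlorophenyl, gives a 1.3-fold higher number from compound 3 to compound 4 (0.10 log units; within the scatter) as its step, so this position accepts the extra chlorine with no change that stands clear of the scatter. Compound 4 also cannot be told apart from the two weaker compounds, with a 1.6-fold lower number from compound 2 to compound 4 (0.20 log units; within the scatter) as one step and a 1.8-fold lower number from compound 1 to compound 4 (0.27 log units; within the scatter) as the other, even though compound 3 is separated from both by more than the scatter. No available measurement explains why the second chloro makes so little difference.

From the compounds shown here alone, whether this position would respond more clearly to an amine, a carboxylic acid or a methoxy group remains open. The compounds shown also leave open whether a second chloro elsewhere on this ring would behave the same way.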